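This account rests on a few compounds, and the source may have more. Where it says the series, first, only, none or still open, it means among the compounds named here.

Compound 1, `CCN1C(=O)C(=O)c2cc(/C=C/C(=O)OC)ccc21`, in a functional assay on HepG2 cells (Homo sapiens) for cytotoxicity, read by MTT assay, with a stated time of 48 h (a higher number here means a weaker inhibitor, a lower number a stronger inhibitor), gives 400 nM.
Compound 2, `COC(=O)/C=C/c1ccc2c(c1)C(=O)C(=O)N2Cc1ccc(C#N)cc1`, in this assay gives 50 nM.

For the measured compounds named here, of these two numbers, compound 1 has the higher one, with compound 2 the nearest and the only comparison: the step of an 8.0-fold lower number from compound 1 to compound 2 (0.90 log units; beyond the scatter) is the one measured change in this set. It concerns the chain carbon bound to the ring nitrogen, where 4-cyanophenyl replaces methyl, and leaves the rest of the core untouched.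

Compound 3, `COC(=O)/C=C/c1ccc2c(c1)C(=O)C(=O)N2`, is not yet measured. It differs from compound 1 in one place: hydrogen in place of ethyl on an amide-type nitrogen in a ring. Going by the values given here, no measured step removes the substituent on the ring nitrogen altogether; the step from compound 1 to compound 2 only enlarges it, so it bears on compound 3 loosely at most. The change to compound 3 goes the other way, stripping the nitrogen bare, and the data give no direction for it. A step about the size of the scatter, or a somewhat higher number, is therefore the expectation in this assay, and the expected step of a 1.8-fold higher number from compound 1 to compound 3 (0.24 log units; within the scatter) is stated in that spirit. Compound 3 is estimated at 700 nM, within 200 nM to 2500 nM.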

Compound 3, half-maximal inhibitory concentration: 370 nM
Compound 3: middle estimate off by 1.9-fold (0.28 log units), on the high side; the range from low to high includes it.
By their numbers in this assay, from the lowest: compound 2; then compounds 3 and 1 (each within the scatter of the next).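

In this assay, replacing the ethyl on the amide-type nitrogen in a ring with hydrogen gives a 1.1-fold lower number from compound 1 to compound 3 (0.03 log units; within the scatter), so removing this group leaves the read-out unchanged within the scatter. The earlier step only enlarged the substituent, whereas this one shows that, in this pair, the ethyl can be lost without a measurable change, with compound 3 at 370 nM and compound 2, which carries the 4-cyanophenyl on the chain carbon, at 50 nM. Nothing available explains why the ethyl and hydrogen compounds read alike.

The compounds shown leave open how other groups on this nitrogen would read: a longer chain such as butyl, or a plain benzyl group lacking the nitrile, would help separate the part played by the phenyl ring from that of the nitrile in compound 2. They also keep the methyl ester fixed throughout, so how a carboxylic acid at that end would read in this assay, with either hydrogen or ethyl on the nitrogen, remains an open question.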